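The source may report more compounds than this note shows. Statements on the series, on what has been measured and on what is new or still open speak of the compounds shown alone.

compound 1 `CC(C)n1ncc2c(C(=O)NCc3cn(-c4ccccc4)nn3)cccc21` — > 40000 nM
compound 2 `Cc1ccc(-n2cc(CNC(=O)c3cccc4c3cnn4C(C)C)nn2)cc1C` — > 40000 nM
compound 3 `CC(C)n1ncc2c(C(=O)NCc3cn(-c4ccc(F)cc4)nn3)cccc21` — > 40000 nM

The three measured compounds share one core and differ only in the group carried on the aromatic nitrogen. In a functional assay on MGC-803 cells (Homo sapiens) for inhibition, read by MTT assay, with a stated time of 72 h (on this read-out lower numbers stand for stronger inhibition and higher numbers for weaker inhibition), compound 1 gives > 40000 nM, which is a limit of the assay. Compound 2 gives > 40000 nM, again a limit. Compound 3 gives > 40000 nM, once more a limit. The steps a step that the two limits leave unreadable from compound 1 to compound 2, a step that the two limits leave unreadable from compound 1 to compound 3 and a step that the two limits leave unreadable from compound 2 to compound 3 are thus not readable in size, since the limit of > 40000 nM in this assay, at which 3 of the 3 values shown sit, holds for every value shown. Compound 3 therefore stands at that limit together with the other two.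

Compound 4 `COc1ccc(-n2cc(CNC(=O)c3cccc4c3cnn4C(C)C)nn2)cc1` differs from compound 3 by methoxy in place of fluoro on an aromatic carbon. Among the compounds with values here, none of the measured steps can be read in size, so none of them gives a direction or a size for this change in this assay. Because (the limit of > 40000 nM in this assay, at which 3 of the 3 values shown sit), compound 4 is expected to give 60000 nM, with a range from 20000 nM to 200000 nM. The step that the limit leaves unreadable from compound 3 to compound 4 is accordingly expected to stay within the scatter.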

Compound 4, half-maximal inhibitory concentration: > 40000 nM
Compound 4 ended at the assay's limit; the forecaster's own chance of this, stated with the estimate: 85%; the middle value lies beyond the limit too.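

Compound 4 sits at the same limit as compound 1, compound 2 and compound 3, so none of its steps to these three compounds can be read in size: the limit of > 40000 nM in this assay, at which 4 of the 4 values shown sit.

In this assay the compounds shown leave open whether any of these groups on the aromatic nitrogen changes inhibition, and by how much.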